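Side-chain end swap from compound 3 to compound 4

A few compounds are considered here, and "the series" means these few. Any claim that something is new, unique, unknown or untested is made for them only; others in the source may bear on it.

In a physicochemical assay for solubility, in phosphate buffer, with a stated time of 18 h, at pH 7.4 (on this read-out lower numbers stand for lower solubility and higher numbers for higher solubility), compound 1 `COc1cc2ncnc(-n3nc(-c4ccccn4)nc3N)c2cc1OCc1ccccc1` gives 58000 nM, compound 2 `COc1cc2ncnc(-n3nc(-c4ccccn4)nc3N)c2cc1OCCCCNC(=O)OC(C)(C)C` gives 500 nM and compound 3 `CCCCCCOC(=O)NCCCOc1cc2c(-n3nc(-c4ccccn4)nc3N)ncnc2cc1OC` gives 1000 nM. Two large steps stand out, a 120-fold lower number from compound 1 to compound 2 (2.06 log units; beyond the scatter) and a 58-fold lower number from compound 1 to compound 3 (1.76 log units; beyond the scatter), whereas a 2.0-fold higher number from compound 2 to compound 3 (0.30 log units; within the scatter) stays within the scatter. Compound 3 thus stands with compound 2 at the low end of the three numbers, far from the top one.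

Compound 4 `COc1cc2ncnc(-n3nc(-c4ccccn4)nc3N)c2cc1OCCCNC(=O)OCC(C)(C)C` differs from compound 3 in one place: tert-butyl in place of pentyl on a saturated chain carbon bound to an oxygen next to a carbonyl group. This is tert-butyl in place of pentyl on a saturated chain carbon bound to an oxygen next to a carbonyl group, or hexyloxycarbonyl to neopentyloxycarbonyl. The nearest evidence is a 2.0-fold higher number from compound 2 to compound 3 (0.30 log units; within the scatter), which also alters the far end of the side chain. The two large steps both replace phenyl, a different kind of change, and carry little weight here. No step beyond the scatter is expected, and the expected size is a 1.2-fold higher number from compound 3 to compound 4 (0.08 log units; within the scatter). For compound 4 the estimated value is 1200 nM, with an expected range of 400 nM to 4000 nM.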

Compound 4, solubility: 200 nM
Estimate against measurement, compound 4: 6.0-fold (0.78 log units) above; the whole stated range lies above it.
By their numbers in this assay, from the lowest: compound 4; then compounds 2 and 3 (each within the scatter of the next); then compound 1.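

In this assay the far end of the side chain is not silent: tert-butyl in place of pentyl on a saturated chain carbon bound to an oxygen next to a carbonyl group gives a step beyond the scatter (a 5.0-fold lower number from compound 3 to compound 4 (0.70 log units; beyond the scatter)), which the earlier side-chain pair did not show. The neopentyloxycarbonyl side chain also separates from the tert-butoxycarbonyl one (a 2.5-fold lower number from compound 2 to compound 4 (0.40 log units; beyond the scatter)), and the gap to the phenyl end group becomes the widest in the set (a 290-fold lower number from compound 1 to compound 4 (2.46 log units; beyond the scatter)). No measurement at hand bears on the cause of these steps.

Open, as far as these compounds go, is whether the branching or the carbon count carries the step; a straight butyl at this place would separate the two. Also open, from the compounds shown here alone, is how an amine or a carboxylic acid at the end of the side chain would read in this assay.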